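The source may report more compounds than this note shows. Statements on the series, on what has been measured and on what is new or still open speak of the compounds shown alone.

Measured compounds:
- compound 1 `O=C(CCCCc1ccccc1)c1nc2ncccc2o1`: 0.3 nM
- compound 2 `CCCCCCCC/C=C\CCCCCCC(=O)c1nc2cccnc2o1`: 11 nM

Both compounds share the same core and carry a carbonyl group linked to a saturated chain. In an assay on isolated protein for inhibition of Fatty-acid amide hydrolase 1 (Homo sapiens) (on this read-out lower numbers stand for stronger inhibition and higher numbers for weaker inhibition), compound 1 gives 0.3 nM, the lowest number of the two. Compound 2, which carries a long unsaturated chain instead, gives 11 nM in this assay, a difference that lies beyond the usual scatter of repeated measurements, so compound 1 stands as the stronger inhibitor of the pair.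

Compound 3 `O=C(CCCc1ccccc1)c1nc2ncccc2o1` has not yet been measured. It differs from compound 1 by phenyl in place of benzyl on a saturated chain carbon, three bonds along the chain from a carbonyl carbon, so the chain between the carbonyl and the aromatic ring is shorter by one carbon. Going by the values given here, no measured pair here shows such a shortening, so the size of its effect is not known from these data. Compound 3 is expected to give a modestly higher number than compound 1, with a step of a 3.3-fold higher number from compound 1 to compound 3 (0.52 log units; beyond the scatter) that may lie just beyond the scatter. The estimate for compound 3 in this assay is 1 nM, within 0.3 nM to 5 nM.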

Compound 3, inhibition constant: 6.9 nM
Estimate against measurement, compound 3: 6.9-fold (0.84 log units) below, outside the stated range (above it).
By their numbers in this assay, from the lowest: compound 1; then compounds 3 and 2 (each within the scatter of the next).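

In this assay, the length of the chain leading to the aromatic ring matters a great deal at this position. Phenyl in place of benzyl on a saturated chain carbon, three bonds along the chain from a carbonyl carbon, gives a 23-fold higher number from compound 1 to compound 3 (1.36 log units; beyond the scatter) even though the aromatic ring and the shared core stay the same, so a one-carbon change is enough to produce a large step. The data offer no explanation for why this small change has such a large effect.

On these data alone, with only these two lengths of the phenyl-ending chain available for comparison, it remains open whether a longer chain would lower the number further or raise it. It is also unknown how an amine or a carboxylic acid in place of the benzyl would behave.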